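The compounds below may be only part of what the source reports. "The series", "measured", "known", "first", "only" and "open" are said of these compounds alone.

Of the compounds shown here, three built on a shared core have been tested in a functional assay on HCT-116 cells (Homo sapiens) for inhibition, read by MTT assay, with a stated time of 48 h; a lower number here means a stronger inhibitor, a higher number a weaker inhibitor. Compound 1, `C=C(C)C(=O)N(Cc1ccc(OC)c(O)c1)c1cc(OC)c(OC)c(OC)c1`, gives 200 nM, the lowest of the two numbers measured. Compound 3, `C/C=C/C(=O)N(Cc1ccc(OC)c(F)c1)c1cc(OC)c(OC)c(OC)c1`, gives 1160 nM, a gap beyond the usual scatter. Compound 2, `COc1cc(NCc2ccc(Br)cc2)cc(OC)c1OC`, reaches only > 80000 nM, which is a limit of the assay rather than a number (the limit of > 80000 nM in this assay, at which 1 of the 3 values shown sits).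

The next compound, compound 4, `COc1ccc(CN(C(=O)C(C)Br)c2cc(OC)c(OC)c(OC)c2)cc1O`, differs from compound 1 in a single place: 1-bromoethyl in place of 1-methylethenyl on a carbonyl carbon. Going by the values given here, no pair of measured compounds shows this change, so the data give no direct guide to its size. The step expected in this assay is a modest weakening, a 2.0-fold higher number from compound 1 to compound 4 (0.30 log units; within the scatter), close to the edge of the scatter. Compound 4 is therefore estimated at 400 nM, with a range from 100 nM to 2000 nM.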

Compound 4, half-maximal inhibitory concentration: 140 nM
Compound 4: middle estimate off by 2.9-fold (0.46 log units), on the high side; the measured number falls inside the stated range.
By their numbers in this assay, from the lowest: compounds 4 and 1 (each within the scatter of the next); then compound 3. At a limit, above all of these: compound 2.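

In this assay the swap on the carbonyl carbon gives no difference that can be read (a 1.4-fold lower number from compound 1 to compound 4 (0.15 log units; within the scatter)). The earlier compounds shown here gave no view of this place alone, and this pair shows that a 1-bromoethyl group, with no double bond outside aromatic rings, matches the 1-methylethenyl group of compound 1 in this assay's numbers. Nothing measured here accounts for this match.

Still open, on these data alone, is whether a plain ethyl group, with no bromine, would hold up at this place. An amine or a longer chain on the same carbonyl carbon is equally untested by the compounds shown.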